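This account rests on a few compounds, and the source may have more. Where it says the series, first, only, none or still open, it means among the compounds named here.

Working notes on a small series read in a functional assay on HeLa cells (Homo sapiens) for cytotoxicity, read by MTT assay, with a stated time of 72 h; a higher number here means a weaker inhibitor, a lower number a stronger inhibitor. Compound 1 `CCCC[C@H](CC)C[C@]1(CC)C=C(CC)/C(=C/C(=O)OC)O1` gives 4200 nM in this assay, the lowest of the three numbers in hand. Compound 2 `CCCCC(C)C/C(=C\[C@@]1(CC)OC(=O)C[C@@H]1O)CC` gives 4700 nM in this assay; the gap to compound 1 lies within the scatter, so no order is drawn between these two. Compound 3 `CCCCC(C)CC(O)(/C=C(/CC)[C@@H](O)CC(=O)OC)CC` gives 15500 nM in this assay, and here the gap to compound 1 lies beyond the scatter. Among the measured compounds shown here, no two of the measured compounds differ in one place only, so no single-change step between measured compounds is available, and any expectation for a new analogue rests on the standing of compound 1 alone.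

Compound 4 `CC/C=C/[C@H](CC)C[C@]1(CC)C=C(CC)/C(=C/C(=O)OC)O1` is the next to be measured. Set against compound 1, the change is but-1-en-1-yl in place of butyl on a saturated chain carbon bound to two saturated chain carbons. The core of compound 1 and all its other substituents are kept. Nothing measured in the series speaks to a change of this kind, so the step expected in this assay is no change at the digits printed from compound 1 to compound 4 (within the scatter), none beyond the scatter. Compound 4 is therefore estimated at 4200 nM in this assay, with the range expected to run from 1800 nM to 10000 nM.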

Compound 4, half-maximal inhibitory concentration: 2600 nM
Beside the measured number, compound 4's estimate is 1.6-fold (0.21 log units) above it, and the stated range covers the measured number.
By their numbers in this assay, from the lowest: compounds 4, 1 and 2 (each within the scatter of the next); then compound 3.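

In this assay, among the compounds shown here, the first single-change step reads a 1.6-fold lower number from compound 1 to compound 4 (0.21 log units; within the scatter) and so gives no shift beyond the scatter. At this place, on a saturated chain carbon bound to two saturated chain carbons, but-1-en-1-yl is thus accepted in place of butyl, with the count of heavy atoms unchanged, a double bond outside aromatic rings added, and the core of compound 1 and its other substituents kept. No measurement at hand explains the number that compound 4 gives, or says what the double bond does here.

Still open, on these data alone, is how far this place tolerates larger departures from butyl, such as a longer chain, a phenyl ring, a terminal hydroxyl or an amine, since one step within the scatter sets no limit on what the chain accepts. For the compounds shown here, also open is whether but-1-en-1-yl would read the same way on the differing structures of compound 2 and compound 3, as the single step here rests on the core of compound 1 alone.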